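The source may hold more compounds than are shown below. What is called first, only, known or untested is meant among the compounds shown, and "the series" means these compounds.

Three compounds sharing one core were tested in a functional assay on KB cells (Homo sapiens) for cytotoxicity, read by MTT assay, with a stated time of 72 h; on this read-out lower numbers stand for stronger inhibition and higher numbers for weaker inhibition. Compound 1 `COc1ccc(S(=O)(=O)c2nc3ccccc3nc2N2CCCC(O)C2)cc1` gives 2120 nM. Compound 2 `O=S(=O)(c1ccc(F)cc1)c1nc2ccccc2nc1N1CCCC(O)C1` gives 18300 nM, and compound 3 `COc1ccc(S(=O)(=O)c2nc3ccccc3nc2N2CCC(O)CC2)cc1` gives 8060 nM, which places compound 3 between the other two.

Two single changes connect these measured compounds. The first, (fluoro in place of methoxy on an aromatic carbon), produced an 8.6-fold higher number from compound 1 to compound 2 (0.94 log units; beyond the scatter). The second changes the core itself: 4-hydroxypiperidin-1-yl in place of 3-hydroxypiperidin-1-yl on an aromatic carbon, which produced a 3.8-fold higher number from compound 1 to compound 3 (0.58 log units; beyond the scatter). For the measured compounds named here, compound 2 and compound 3 differ in both places at once, so no single step joins them; their values simply show that compound 2 sits at the weaker end of the three.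

Compound 4 `O=S(=O)(c1ccc(F)cc1)c1nc2ccccc2nc1N1CCC(O)CC1` has not yet been measured. It is related to compound 3 by fluoro in place of methoxy on an aromatic carbon, the same change that separated compound 1 from compound 2, made on the core of compound 3 rather than the core of compound 1. Going by the values given here, because compound 1 lost ground to compound 2 by an 8.6-fold higher number from compound 1 to compound 2 (0.94 log units; beyond the scatter), the same change on compound 3 is expected to move in the same direction, giving an estimated step of a 7.4-fold higher number from compound 3 to compound 4 (0.87 log units; beyond the scatter); the size is taken as similar since the surroundings of the change are the same in both pairs, though only two compounds support that expectation. On this basis compound 4 is expected to give about 60000 nM in this assay, with a plausible range from 20000 nM to 180000 nM.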

Compound 4, half-maximal inhibitory concentration: 9580 nM
Beside the measured number, compound 4's estimate is 6.3-fold (0.80 log units) above it, outside the stated range (below it).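

In this assay, fluoro in place of methoxy on the core of compound 3 gives a 1.2-fold higher number from compound 3 to compound 4 (0.08 log units; within the scatter), and 4-hydroxypiperidin-1-yl in place of 3-hydroxypiperidin-1-yl, with the 4-fluorophenyl group in place, gives a 1.9-fold lower number from compound 2 to compound 4 (0.28 log units; within the scatter). The step from 4-methoxyphenyl to 4-fluorophenyl therefore does not carry over in size from one core to the other, and what it does depends on which hydroxypiperidine is present: the same change on two cores in this assay, an 8.6-fold higher number (0.94 log units; beyond the scatter) from compound 1 to compound 2 and a 1.2-fold higher number (0.08 log units; within the scatter) from compound 3 to compound 4, 7.3-fold (0.86 log units) apart, beyond the scatter of two such steps. The hydroxypiperidine change shows the same dependence, but these two comparisons rest on the same four compounds, so they are one finding rather than two, and they show neither why the steps differ nor whether the dependence extends beyond this set: the same change on two cores in this assay, a 3.8-fold higher number (0.58 log units; beyond the scatter) from compound 1 to compound 3 and a 1.9-fold lower number (0.28 log units; within the scatter) from compound 2 to compound 4, 7.3-fold (0.86 log units) apart, beyond the scatter of two such steps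

The compounds shown leave open how other groups in place of methoxy, such as chloro, methyl or a dimethylamino group, would behave on each of the two cores. They also leave open whether the dependence would persist if the hydroxyl on the piperidine gave way to an amine or a carboxylic acid.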